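The source may report more compounds than this note shows. Statements on the series, on what has been measured and on what is new or still open speak of the compounds shown alone.

In a functional assay on HT-29 cells (Homo sapiens) for cytotoxicity, read by sulforhodamine B assay, with a stated time of 72 h (a lower number here means a stronger inhibitor of growth, a higher number a weaker inhibitor of growth), three compounds have been measured:

Compound 1 `C=C1CC[C@@H]2[C@](C)(CCC[C@]2(C)C(=O)O)[C@H]1CCc1ccc2c(OC(C)=O)ccc(OC(C)=O)c2c1`: 240 nM
Compound 2 `C=C1CC[C@@H]2[C@](C)(CCC[C@]2(C)C(=O)OC)[C@H]1CCC1=CCc2c(OC(C)=O)ccc(OC(C)=O)c2C1`: 1380 nM
Compound 3 `C=C1CC[C@@H]2[C@](C)(CCC[C@]2(C)C(=O)OC)[C@H]1CCc1ccc2c(OCc3ccccc3)ccc(OCc3ccccc3)c2c1`: > 5000 nM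

Compound 3 gives > 5000 nM, which is a limit of the assay and not a number. It is the only one of the three without a measured number.

Compound 4 `C=C1CC[C@@H]2[C@](C)(CCC[C@]2(C)C(=O)OCc2ccccc2)[C@H]1CCc1ccc2c(OCc3ccccc3)ccc(OCc3ccccc3)c2c1` differs from compound 3 in one place: phenyl in place of hydrogen on a saturated chain carbon bound to an oxygen next to a carbonyl group. Methoxycarbonyl thus becomes benzyloxycarbonyl. Among the measured compounds shown here, no measured pair shows this change alone, so the expectation is for no shift in this assay beyond the scatter, with any drift towards weaker growth inhibition. The expected step is a step that the limit leaves unreadable from compound 3 to compound 4, and the result may well be only a limit again. For compound 4 the estimated value is 7000 nM, within an expected range of 3000 nM to 20000 nM.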

Compound 4, concentration for 50% growth inhibition: 4400 nM
Compound 4: middle estimate off by 1.6-fold (0.20 log units), on the high side; the range from low to high includes it.
By their numbers in this assay, from the lowest: compound 1; then compound 2; then compound 4. At a limit, above all of these: compound 3.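

Compound 4 gives a measured number where compound 3 gave only a limit, so benzyloxycarbonyl at this place still leaves growth inhibition that can be read in this assay. Methyl to benzyl gives an at least 1.1-fold lower number from compound 3 to compound 4 (0.05 log units; that floor lies within the scatter), which does not establish a real change. The true size of the step stays open because one end of it is a limit: the limit of > 5000 nM in this assay, at which 1 of the 4 values shown sits.

Going by these compounds, it remains open how an amide or an ethyl ester would read at this place. Whether a substituted benzyl group would move the number is also unknown.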